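A guanidine side chain swap on the aryl ethyl core

The source may report more compounds than this note shows. Statements on the series, on what has been measured and on what is new or still open speak of the compounds shown alone.

Among the measured compounds shown here, compound 1 `COc1ccc(Br)cc1CCc1c(F)cccc1C(=O)/N=C(\N)NCC(C)C` is one of three compounds measured in an assay for binding affinity to Melanocortin receptor 4 (Homo sapiens); a higher number here means a weaker inhibitor, a lower number a stronger inhibitor. In this assay compound 1 gives 770 nM. Compound 2 `CCN(CC)CCCC(C)/N=C(/N)NC(=O)c1cccc(F)c1CCc1ccc2ccccc2c1` gives 690 nM in this assay, a number within the scatter of that of compound 1. Compound 3 `CCN(CC)CCCC(C)/N=C(/N)NC(=O)c1cccc(F)c1CCc1cccc2ccccc12` gives 89 nM in this assay, a number beyond the scatter below both. For the measured compounds named here, the only measured step in the set is a 7.8-fold lower number from compound 2 to compound 3 (0.89 log units; beyond the scatter), and it concerns a change on the aryl side of the core.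

Compound 4 `COc1ccc(Br)cc1CCc1c(F)cccc1C(=O)/N=C(\N)NCCCN1CCN(C)CC1` differs from compound 1 by 2-(4-methylpiperazin-1-yl)ethyl in place of isopropyl on a saturated chain carbon bound to an amine nitrogen. Going by the values given here, no measured pair shows this kind of change: compounds 2 and 3 carry a different group on the saturated chain carbon bound to the amine nitrogen, but they also differ from compound 1 elsewhere, so their values cannot be read as a step for this change. The size of the step in this assay from compound 1 to compound 4 is therefore uncertain, and a wide range is needed; a change no larger than modest is expected, with a 1.9-fold lower number from compound 1 to compound 4 (0.28 log units; within the scatter). Compound 4 is estimated at 400 nM, with a range from 100 nM to 1500 nM.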

Compound 4, inhibition constant: 64 nM
Compound 4: the middle estimate sits 6.3-fold (0.80 log units) above what was measured; measured number outside the range, below it.
By their numbers in this assay, from the lowest: compounds 4 and 3 (each within the scatter of the next); then compounds 2 and 1 (each within the scatter of the next).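

On the core of compound 1, the place on a saturated chain carbon bound to an amine nitrogen proves highly responsive in this assay: 2-(4-methylpiperazin-1-yl)ethyl in place of isopropyl gives a 12-fold lower number from compound 1 to compound 4 (1.08 log units; beyond the scatter), a large step. Among the compounds shown here, the earlier set held only a step on the aryl side, so this is the first sign that the side chain alone, with the rest of compound 1 unchanged, can move the number beyond the scatter. Nothing available here accounts for the size of this step.

The compounds shown do not separate the contribution of the 4-methylpiperazine ring from that of the longer chain, which a morpholine or a simple dimethylamino group on the same propyl chain would address. Going by these compounds, whether the step carries over to the naphthyl compounds also stays open.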